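The source may report more compounds than this note shows. Statements on the series, on what has been measured and on what is new or still open speak of the compounds shown alone.

Of the compounds shown here, three built on one shared core have been measured in a functional assay on CHO cells for antagonist activity at Orexin/Hypocretin receptor type 1 (Homo sapiens), read by FLIPR and calcium flux; a lower number here means a stronger inhibitor, a higher number a weaker inhibitor. Compound 1, `CCc1nc(Cl)c2n1CCN([C@@H](C(=O)NC)c1ccccc1)[C@H]2COc1ccc(C(F)(F)F)cc1`, gives 431 nM; compound 2, `CCc1nc(Cl)c2n1CCN([C@@H](C(=O)NC)c1ccccc1)[C@H]2COc1cccc(C(F)(F)F)c1`, gives 312 nM; compound 3, `CCc1nc(Cl)c2n1CCN([C@@H](C(=O)NC)c1ccccc1)[C@H]2CCc1ccc(C(F)(F)F)c(Cl)c1`, gives 20 nM, the strongest of the three, with a 22-fold lower number from compound 1 to compound 3 (1.33 log units; beyond the scatter) and a 16-fold lower number from compound 2 to compound 3 (1.19 log units; beyond the scatter). Compound 4, `CCc1nc(Cl)c2n1CCN([C@@H](C(=O)NC)c1ccccc1)[C@H]2CCc1cc(F)c(C(F)(F)F)cc1F`, differs from compound 3 only in the aromatic group at the end of the chain: 2,5-difluoro-4-(trifluoromethyl)phenyl in place of 3-chloro-4-(trifluoromethyl)phenyl on a saturated chain carbon, two bonds along the chain from a saturated ring carbon. Going by the values given here, no measured step alters the substituents on that group while keeping the chain; the nearest comparison, a 1.4-fold lower number from compound 1 to compound 2 (0.14 log units; within the scatter), changed only the trifluoromethyl placement on a phenyl on an oxygen and stayed within the scatter. A small step, if any, is therefore expected in this assay. Compound 4 is expected to give 25 nM, within 8 nM to 80 nM, meaning a 1.3-fold higher number from compound 3 to compound 4 (0.10 log units; within the scatter).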

Compound 4, half-maximal inhibitory concentration: 32 nM
Compound 4: the middle estimate sits 1.3-fold (0.11 log units) below what was measured; the range from low to high includes it.
By their numbers in this assay, from the lowest: compounds 3 and 4 (each within the scatter of the next); then compounds 2 and 1 (each within the scatter of the next).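

With the chain kept, the substituents on the end group can be exchanged in this assay with a 1.6-fold higher number from compound 3 to compound 4 (0.20 log units; within the scatter) as the only result, so 2,5-difluoro-4-(trifluoromethyl)phenyl and 3-chloro-4-(trifluoromethyl)phenyl cannot be told apart here. The earlier steps shown here changed the trifluoromethyl placement on a phenyl on an oxygen or replaced the whole phenoxy group, never only the substituents on this chain-bound ring. Nothing available explains this result. Still open, going by these compounds, is whether the ring needs its trifluoromethyl at all, and how an amine or a carboxylic acid on that ring, or a longer chain, would fare.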